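From a nitrile to a dimethylamino group

The source may report more compounds than this note shows. Statements on the series, on what has been measured and on what is new or still open speak of the compounds shown alone.

In a functional assay on MCF7 cells (Homo sapiens) for inhibition, read by CCK-8 assay, with a stated time of 48 h (on this read-out higher numbers stand for weaker inhibition and lower numbers for stronger inhibition), compound 1 (`COc1cc(-c2ccnc3cc(-c4ccc(F)cc4)nn23)cc(OC)c1OC`) gives 1280 nM, and compound 2 (`Cn1ccc2cc(-c3cc4nccc(-c5ccc(F)cc5)n4n3)ccc21`) gives 4580 nM. Compound 3 (`COc1cc(-c2ccnc3cc(-c4cccc(C#N)c4)nn23)cc(OC)c1OC`) gives > 10000 nM, which is a limit of the assay and not a number. Compound 4 (`COc1cc(-c2ccnc3cc(-c4ccc(N(C)C)cc4)nn23)cc(OC)c1OC`) changes a single group of compound 3: 4-(dimethylamino)phenyl in place of 3-cyanophenyl on an aromatic carbon. Among the compounds with values here, the one measured step that bears on this is an at least 7.8-fold higher number from compound 1 to compound 3 (0.89 log units; beyond the scatter), where 3-cyanophenyl took the place of 4-fluorophenyl on an aromatic carbon. Removing 3-cyanophenyl may therefore recover some inhibition, although a single step establishes no rule. The expected change in this assay is an at least 3.3-fold lower number from compound 3 to compound 4 (0.52 log units; beyond the scatter), toward stronger inhibition. Compound 4 is estimated at 3000 nM, with an expected range of 800 nM to 10000 nM.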

Compound 4, half-maximal inhibitory concentration: 44 nM
The estimate for compound 4 lay 68-fold (1.83 log units) above the measured number; the whole stated range lies above it.
By their numbers in this assay, from the lowest: compound 4; then compound 1; then compound 2. At a limit, above all of these: compound 3.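

Within the data shown here, until now the only change seen at this position was a loss, but it can also bring a strong gain: in this assay there is a 29-fold lower number from compound 1 to compound 4 (1.46 log units; beyond the scatter), with only the group on the phenyl ring changed. The other step, an at least 220-fold lower number from compound 3 to compound 4 (2.35 log units; beyond the scatter), gives only a minimum size. Compound 3 stands at a limit of the assay, not at a number: the limit of > 10000 nM in this assay, at which 1 of the 4 values shown sits.

As far as these compounds go, how a primary amine or a morpholine in this place would compare with dimethylamino stays open. So does whether dimethylamino would bring a similar gain on the core of compound 2.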